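The compounds below may be only part of what the source reports. "The series", "measured", "known", "first", "only" and "open" are said of these compounds alone.

Measured in a functional assay on MDA-MB-231 cells (Homo sapiens) for inhibition, read by MTT assay, with a stated time of 48 h; on this read-out higher numbers stand for weaker inhibition of growth and lower numbers for stronger inhibition of growth:
- Compound 1 `CC(C)c1ccc(Nc2ncnc3ccc(NC(=S)NCc4ccccc4)cc23)cc1`: 12800 nM
- Compound 2 `N=C(N)NS(=O)(=O)c1ccc(Nc2ncnc3ccc(NC(=S)NCc4ccccc4)cc23)cc1`: > 30000 nM, a limit of the assay
- Compound 3 `Oc1ccc(NC(=S)Nc2ccc3ncnc(Nc4cccc(Br)c4)c3c2)cc1`: 17300 nM

Compound 3 gives 17300 nM and compound 1 gives 12800 nM, two values within the scatter of each other. Compound 2, at > 30000 nM, gives only a limit and no number.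

Compound 4 `FC(F)(F)c1cccc(NC(=S)Nc2ccc3ncnc(Nc4cccc(Br)c4)c3c2)c1` carries 3-(trifluoromethyl)phenyl in place of the 4-hydroxyphenyl of compound 3 on an amide-type nitrogen: 3-(trifluoromethyl)phenyl in place of 4-hydroxyphenyl on an amide-type nitrogen.

Among the compounds with values here, only one step has been measured, an at least 2.3-fold higher number from compound 1 to compound 2 (0.36 log units; beyond the scatter), and it rests on a limit. That change lies in a different place, on an aromatic carbon, so it bears only loosely on this one. Within the data shown here, no measured step changes the group on the amide-type nitrogen alone. The closest guide is that compound 1, at 12800 nM, lies within the scatter of compound 3 although its group on that nitrogen is different. No clear direction can therefore be drawn, and the expected change is small: a 1.3-fold lower number from compound 3 to compound 4 (0.12 log units; within the scatter), estimated to stay within the scatter in this assay. Compound 4 is estimated at 13000 nM, with an expected range from 5000 nM to 30000 nM.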

Compound 4, concentration for 50% growth inhibition: 1400 nM
Estimate against measurement, compound 4: 9.3-fold (0.97 log units) above; measured number below the stated range.
By their numbers in this assay, from the lowest: compound 4; then compounds 1 and 3 (each within the scatter of the next). At a limit, above all of these: compound 2.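

In this assay the group on the amide-type nitrogen, whose other neighbour is the thiocarbonyl carbon, proves to have a large effect: 3-(trifluoromethyl)phenyl in place of 4-hydroxyphenyl gives a 12-fold lower number from compound 3 to compound 4 (1.09 log units; beyond the scatter) and so moves the number well towards stronger inhibition of growth. Within the data shown here, the earlier compounds held no step at this position; their only step lay on an aromatic carbon and rested on a limit, so this is the first measured sign that growth inhibition responds to this group alone, with the rest of the structure held constant. The exchange alters both the group on the ring and where it stands, so this one step cannot separate the two, and nothing measured here bears on the cause of the step.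

The compounds shown leave open how an unsubstituted phenyl or a 4-(trifluoromethyl)phenyl would stand on this nitrogen, which would tell the group apart from its place on the ring. Going by these compounds, it also remains open whether a chlorine, a methoxy or a nitrile on that ring would follow the same course, and whether the step holds when the rest of the molecule changes.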